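Moving from methyl to two chlorines on the urea aryl ring

The compounds below may be only part of what the source reports. "The series", "measured", "known", "first", "only" and "open" are said of these compounds alone.

Three ureas share one core, differing only in the aryl group on the amide-type nitrogen. Compound 1 `Cc1cccc(NC(=O)Nc2nnc(Sc3ncnc4scc(-c5ccncc5)c34)s2)c1` gives 20700 nM in a functional assay on HepG2 cells (Homo sapiens) for antiproliferative activity, read by MTT assay, with a stated time of 48 h (a higher number here means a weaker inhibitor, a lower number a stronger inhibitor), compound 2 `O=C(Nc1cccc(Cl)c1)Nc1nnc(Sc2ncnc3scc(-c4ccncc4)c23)s1` gives 22900 nM, and compound 3 `Cc1ccc(NC(=O)Nc2nnc(Sc3ncnc4scc(-c5ccncc5)c34)s2)cc1` gives 52000 nM, the highest number of the three, so compound 3 is the weakest inhibitor here. Compound 4 `O=C(Nc1ccc(Cl)c(Cl)c1)Nc1nnc(Sc2ncnc3scc(-c4ccncc4)c23)s1` carries 3,4-dichlorophenyl in place of 4-methylphenyl on an amide-type nitrogen. Going by the values given here, two measured steps bear on this: a 2.3-fold higher number from compound 2 to compound 3 (0.36 log units; beyond the scatter) and a 1.1-fold higher number from compound 1 to compound 2 (0.04 log units; within the scatter). Undoing the methyl-to-chlorophenyl switch is therefore expected to lower the number modestly, while the second chlorine has no precedent among these compounds. For compound 4 the estimate is 20000 nM, within 8000 nM to 50000 nM, an expected step of a 2.6-fold lower number from compound 3 to compound 4 (0.41 log units; beyond the scatter).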

Compound 4, half-maximal inhibitory concentration: 61900 nM
Compound 4: the middle estimate sits 3.1-fold (0.49 log units) below what was measured; measured number above the stated range.
By their numbers in this assay, from the lowest: compounds 1 and 2 (each within the scatter of the next); then compounds 3 and 4 (each within the scatter of the next).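

In this assay, adding a second chlorine to the ring of compound 2 weakens inhibition modestly, a 2.7-fold higher number from compound 2 to compound 4 (0.43 log units; beyond the scatter), and the step from the 3-methylphenyl urea agrees, a 3.0-fold higher number from compound 1 to compound 4 (0.48 log units; beyond the scatter). Exchanging 4-methylphenyl for 3,4-dichlorophenyl gives a 1.2-fold higher number from compound 3 to compound 4 (0.08 log units; within the scatter), so the two aryl groups numbered with a 4 stand together, with higher numbers than the two numbered with a 3 alone. No available evidence explains this difference. From the compounds shown here alone, whether a methoxy group or an amine on this aryl ring would lower the number remains open, as does the result for an unsubstituted phenyl ring.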